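From Carboxy to Pyridylmethyl Carbamoyl on a Shared Core

This account rests on a few compounds, and the source may have more. Where it says the series, first, only, none or still open, it means among the compounds named here.

Compound 1 `COc1ncc(-c2ccc3ncc(C(=O)O)n3c2)cc1NS(=O)(=O)c1ccc(F)cc1F` carries a carboxy group on the shared core. In a functional assay on HCT-116 cells (Homo sapiens) for antiproliferative activity, read by sulforhodamine B assay, with a stated time of 72 h (a higher number here means a weaker inhibitor, a lower number a stronger inhibitor), compound 1 gives 1310 nM. Going by the values given here, of the two numbers measured so far, compound 1 holds the highest; its nearest neighbour is compound 2 `COc1ncc(-c2ccc3ncc(C(=O)N4CCC(OC(=O)c5ccccc5)CC4)n3c2)cc1NS(=O)(=O)c1ccc(F)cc1F`, which in this assay gives 1230 nM, and the gap between the two lies within the scatter, so neither can be placed ahead of the other.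

Compound 3 `COc1ncc(-c2ccc3ncc(C(=O)NCc4ccncc4)n3c2)cc1NS(=O)(=O)c1ccc(F)cc1F` has not yet been measured. It differs from compound 1 in one place: ((pyridin-4-yl)methyl)amino in place of hydroxy on a carbonyl carbon. Among the compounds with values here, no step between measured compounds covers this exact change. In this assay compound 1 gives 1310 nM and compound 2 gives 1230 nM, the two lying within the scatter of each other. On that basis the expected step for compound 3 is a 1.3-fold lower number from compound 1 to compound 3 (0.12 log units; within the scatter), that is, none beyond the scatter in either direction. The estimate for compound 3 in this assay is 1000 nM, expected to fall between 350 nM and 2800 nM.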

Compound 3, half-maximal inhibitory concentration: 310 nM
The estimate for compound 3 lay 3.2-fold (0.51 log units) above the measured number, outside the stated range (below it).
By their numbers in this assay, from the lowest: compound 3; then compounds 2 and 1 (each within the scatter of the next).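

Replacing hydroxy with ((pyridin-4-yl)methyl)amino on a carbonyl carbon gives a 4.2-fold lower number from compound 1 to compound 3 (0.63 log units; beyond the scatter) in this assay, which shows that the number in this assay responds to what is attached at this place. The earlier compounds shown here did not show this: compound 1 at 1310 nM and compound 2 at 1230 nM lie within the scatter of each other, although they carry different groups on that carbonyl carbon. Taken together, the three compounds show that a different group here does not by itself bring a lower number, since only the ((pyridin-4-yl)methyl)amino group of compound 3 moves the value beyond the scatter, and nothing shown here offers a measured reason for this step.

The compounds shown leave open whether the step depends on the nitrogen of the six-membered aromatic ring, a question that a benzylamino group on the same carbonyl carbon would address. They also leave open how the length of the chain bears on the result, which a 2-(pyridin-4-yl)ethylamino group, with its longer chain, would begin to answer.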